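This account rests on a few compounds, and the source may have more. Where it says the series, first, only, none or still open, it means among the compounds named here.

Three compounds share one core and differ only in the group on the sulfonyl sulfur. Compound 1 `O=C(NS(=O)(=O)C1CC1)c1ccc(Nc2nc(NC3(c4ccc(Cl)cc4)CC3)nc(OCC(F)(F)F)n2)cc1` carries a cyclopropyl there, and in an ADME assay on microsomes from liver (Rattus norvegicus) for metabolic stability, with a stated time of 10 min (on this read-out lower numbers stand for a less stable compound and higher numbers for a more stable compound), compound 1 gives 85%. Compound 2 `CS(=O)(=O)NC(=O)c1ccc(Nc2nc(NC3(c4ccc(Cl)cc4)CC3)nc(OCC(F)(F)F)n2)cc1` carries a methyl, and in this assay compound 2 gives 85%. Compound 3 `COC(=O)NCCS(=O)(=O)NC(=O)c1ccc(Nc2nc(NC3(c4ccc(Cl)cc4)CC3)nc(OCC(F)(F)F)n2)cc1` carries a 2-((methoxycarbonyl)amino)ethyl, and in this assay compound 3 gives 100%, the highest of the three. The steps show no change at the digits printed from compound 1 to compound 2 (within the scatter), a number 15 percentage points higher from compound 1 to compound 3 (beyond the scatter) and a number 15 percentage points higher from compound 2 to compound 3 (beyond the scatter).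

Compound 4 `Cc1ccccc1S(=O)(=O)NC(=O)c1ccc(Nc2nc(NC3(c4ccc(Cl)cc4)CC3)nc(OCC(F)(F)F)n2)cc1` is the next step: 2-methylphenyl in place of 2-((methoxycarbonyl)amino)ethyl on a sulfonyl sulfur. The two measured steps that bear on it, from compound 1 and compound 2 to compound 3, both gained the same modest amount when the methoxycarbonylamino-ethyl chain came in; compound 4 now loses that chain, and its 2-methylphenyl is an aromatic ring unlike any group measured here. The expectation is therefore a modest fall, a number 18 percentage points lower from compound 3 to compound 4 (beyond the scatter), back toward the level of compound 1 and compound 2. In this assay compound 4 is estimated at 82%, with a range from 60% to 100%.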

Compound 4, percent of the compound remaining: 100%
Estimate against measurement, compound 4: 18 percentage points below; measured number inside the range.
By their numbers in this assay, from the lowest: compounds 1 and 2 (each within the scatter of the next); then compounds 3 and 4 (each within the scatter of the next).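

In this assay there is no change at the digits printed from compound 3 to compound 4 (within the scatter), so at this sulfonyl sulfur the higher number does not depend on the 2-((methoxycarbonyl)amino)ethyl chain. A 2-methylphenyl, with the same count of heavy atoms but an aromatic ring of carbon only and no hydrogen-bond donors or acceptors, takes its place and still gives a number 15 percentage points higher from compound 2 to compound 4 (beyond the scatter) and a number 15 percentage points higher from compound 1 to compound 4 (beyond the scatter), so two very different groups reach the same level above methyl and cyclopropyl. Nothing measured here explains why these two groups stand level.

From the compounds shown here alone, it stays open whether the aromatic ring alone is enough, which a plain phenyl without the methyl would test. Going by these compounds, it is also open how a simple longer alkyl chain, or a chain ending in an amine or a carboxylic acid, would behave on this sulfur.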